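From carboxy to hydroxymethyl in compound 4

The source may report more compounds than this note shows. Statements on the series, on what has been measured and on what is new or still open speak of the compounds shown alone.

Within the data shown here, in a functional assay on Caco-2 cells (Homo sapiens) for antiproliferative activity, read by MTT assay, with a stated time of 48 h (a higher number here means a weaker inhibitor, a lower number a stronger inhibitor), compound 3 (`CCn1c(C(=O)NC(C)C(=O)O)ccc1C(CC)(CC)c1ccc(OCCC(O)(CC)CC)c(C)c1`) gives 46500 nM, the only true number among the three compounds measured so far. Compound 1 (`C#CCCOC(=O)c1ccc(C(CC)(CC)c2ccc(OCCC(O)(CC)CC)c(C)c2)n1CC`) gives > 50000 nM, which is a limit of the assay. Compound 2 (`CCn1c(C(=O)Nc2cccc(C(F)(F)F)c2)ccc1C(CC)(CC)c1ccc(OCCC(O)(CC)CC)c(C)c1`) gives > 50000 nM, which is also a limit. The remaining analogue, compound 4 (`CCn1c(C(=O)NC(C)CO)ccc1C(CC)(CC)c1ccc(OCCC(O)(CC)CC)c(C)c1`), differs from compound 3 in one place: hydroxymethyl in place of carboxy on a saturated chain carbon bound to an amide-type nitrogen and a saturated chain carbon. Hydroxymethyl stands in place of carboxy on a saturated chain carbon bound to an amide-type nitrogen and a saturated chain carbon.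

Three measured steps alter the group on the same carbonyl carbon, but none makes this exchange. Among the measured compounds shown here, the first is a step that the two limits leave unreadable from compound 1 to compound 2. The other two are an at least 1.0-fold lower number from compound 1 to compound 3 (0.03 log units; that floor lies within the scatter) and an at least 1.0-fold lower number from compound 2 to compound 3 (0.03 log units; that floor lies within the scatter). For the measured compounds named here, these steps show no change that can be told from the scatter, so they offer no precedent for a large shift in this assay. With no step beyond the scatter to draw on, compound 4 is expected to stay in the same weak range as compound 3 at 46500 nM. Compound 4 may well reach the limit of the assay. The estimated change, with no direction beyond the scatter expected, is a 1.1-fold lower number from compound 3 to compound 4 (0.04 log units; within the scatter). For compound 4 the estimated value is 42000 nM, with an expected range from 16000 nM to 75000 nM.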

Compound 4, half-maximal inhibitory concentration: > 50000 nM
Compound 4 ended at the assay's limit (the forecaster's own chance of this, stated with the estimate: 45%); at least 1.1-fold (0.07 log units) between middle value and limit.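

In this assay, hydroxymethyl in place of carboxy on the saturated chain carbon bound to an amide-type nitrogen gives an at least 1.0-fold higher number from compound 3 to compound 4 (0.03 log units; that floor lies within the scatter), so this first change made at this position alone shows no shift that can be told from the scatter. Compound 4 gives > 50000 nM, which is a limit of the assay, so the exchange leaves this compound without a true number and shows only that hydroxymethyl at this place brings no gain that the assay can detect. The steps joining compound 1 and compound 2 to compound 4 cannot be read, and the results now gather at one point: the limit of > 50000 nM in this assay, at which 3 of the 4 values shown sit.

From the compounds shown here alone, whether any group at this carbon could bring the number clearly down remains open, since neither carboxy nor hydroxymethyl gives a step beyond the scatter. An amine or a longer chain such as hydroxyethyl in place of carboxy would test this position further, and the compounds shown give no basis for predicting the outcome of either exchange.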